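Compound 4: one fluorine in place of a larger group

The source may report more compounds than this note shows. Statements on the series, on what has been measured and on what is new or still open speak of the compounds shown alone.

Values measured in a functional assay on LNCaP cells (Homo sapiens) for antiproliferative activity, read by propidium iodide staining, with a stated time of 96 h (on this read-out lower numbers stand for stronger inhibition and higher numbers for weaker inhibition), are these
compound 1 `CC(O)(CSc1ccc(S(F)(F)(F)(F)F)cc1)C(=O)Nc1ccc([N+](=O)[O-])c(C(F)(F)F)c1` gives 8700 nM
compound 2 `CC(O)(CSc1cccc(S(F)(F)(F)(F)F)c1)C(=O)Nc1ccc([N+](=O)[O-])cc1C(F)(F)F` gives 12700 nM
compound 3 `CC(O)(CSc1ccc(S(F)(F)(F)(F)F)cc1)C(=O)Nc1ccc(S(F)(F)(F)(F)F)cc1` gives 18300 nM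

Compound 3 lies within the scatter of compound 2. Its number is higher than that of compound 1, by a gap beyond the scatter. Compound 4 `CC(O)(CSc1ccc(F)cc1)C(=O)Nc1ccc(S(F)(F)(F)(F)F)cc1` differs from compound 3 as follows one fluorine atom in place of a group of 6 heavy atoms (5 fluorine, 1 sulfur; no ring), on an aromatic carbon and the change sits on an aromatic carbon. Among the measured compounds shown here, no measured pair shows this change, so any expectation here is weakly grounded. The expected result is a 1.2-fold lower number from compound 3 to compound 4 (0.09 log units; within the scatter) and this is no shift beyond the scatter. The estimate for compound 4 is 15000 nM with an expected range from 7000 nM to 35000 nM in this test.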

Compound 4, half-maximal inhibitory concentration: 12500 nM
The estimate for compound 4 lay 1.2-fold (0.08 log units) above the measured number; the measured number falls inside the stated range.
By their numbers in this assay, from the lowest: compounds 1, 4, 2 and 3 (each within the scatter of the next, the first and the last beyond it).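

In this assay, exchanging the group of 6 heavy atoms (5 fluorine, 1 sulfur) for one fluorine brings a 1.5-fold lower number from compound 3 to compound 4 (0.17 log units; within the scatter), a step within the scatter. At this aromatic carbon, para to a large group, the read-out therefore does not separate these two very differently sized groups. No other data bear on this result. The compounds shown leave open whether an amine, a methoxy group or a plain hydrogen on this carbon would also stay within the scatter. They also leave open whether the same exchange would do so with a nitro group on the other aromatic ring.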